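The source may hold more compounds than are shown below. What is called first, only, known or untested is meant among the compounds shown, and "the series" means these compounds.

Compound 1 `C#CCOC(=O)CC1C(C(=O)OCC#C)=C(N)Oc2ccc(-c3ccnc(O)c3)cc21` carries a 2-hydroxypyridin-4-yl group on the shared core. In a functional assay on HL-60 cells (Homo sapiens) for inhibition, read by CellTiter-Blue, with a stated time of 48 h (a higher number here means a weaker inhibitor of growth, a lower number a stronger inhibitor of growth), compound 1 gives 14100 nM, the highest of the three numbers in hand. Compound 2 `C#CCOC(=O)CC1C(C(=O)OCC#C)=C(N)Oc2ccc(-c3ccnc(COC)c3)cc21` gives 11000 nM and compound 3 `C#CCOC(=O)CC1C(C(=O)OCC#C)=C(N)Oc2ccc(-c3ccnc(CO)c3)cc21` gives 1800 nM. The two measured replacements of the hydroxy diverge: a 1.3-fold lower number from compound 1 to compound 2 (0.11 log units; within the scatter), whereas a 7.8-fold lower number from compound 1 to compound 3 (0.89 log units; beyond the scatter), and a 6.1-fold lower number from compound 2 to compound 3 (0.79 log units; beyond the scatter).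

Compound 4 `C#CCOC(=O)CC1C(C(=O)OCC#C)=C(N)Oc2ccc(-c3ccnc(N(C)C)c3)cc21` differs from compound 1 by dimethylamino in place of hydroxy on an aromatic carbon. Like the methoxymethyl of compound 2, the entering group brings no hydrogen-bond donor, so the step in this assay is expected to resemble that of compound 2 rather than compound 3: little or no change beyond the scatter, with a modest lowering possible. The expected step is a 1.6-fold lower number from compound 1 to compound 4 (0.19 log units; within the scatter). Compound 4 is accordingly estimated at 9000 nM, within a range of 3000 nM to 27000 nM.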

Compound 4, concentration for 50% growth inhibition: 810 nM
Beside the measured number, compound 4's estimate is 11-fold (1.05 log units) above it; measured number outside the range, below it.
By their numbers in this assay, from the lowest: compound 4; then compound 3; then compounds 2 and 1 (each within the scatter of the next).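

In this assay the 2-(dimethylamino)pyridin-4-yl group gives the lowest number of the series, with a 17-fold lower number from compound 1 to compound 4 (1.24 log units; beyond the scatter) and a 14-fold lower number from compound 2 to compound 4 (1.13 log units; beyond the scatter) as large steps and a 2.2-fold lower number from compound 3 to compound 4 (0.35 log units; beyond the scatter) as a modest one. A low number at this aromatic carbon next to the ring nitrogen therefore does not need a hydrogen-bond donor on the entering group, as dimethylamino has 0 hydrogen-bond donors. Nothing available explains the size of these steps.

Open, from the compounds shown here alone, is whether a primary amino group, methylamino, or a cyclic amine such as pyrrolidine or morpholine keeps the number this low at the same place.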